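This account rests on a few compounds, and the source may have more. Where it says the series, first, only, none or still open, it means among the compounds named here.

Measured compounds:
compound 1 `CC(=O)c1c(C)nc2c(OCc3ccccc3)cccn12` — 57%
compound 2 `Cc1nc2c(OCc3ccccc3)cccn2c1Cl` — 93%
compound 3 `Cc1nc2c(OCc3ccccc3)cccn2c1CC(=O)O` — 12%

In a functional assay on the whole organism with Rattus norvegicus as the target, with a stated time of 4 h, at a dose of 40 mg/kg by the intraperitoneal route (a lower number here means less inhibition, a higher number more inhibition at the dose given (going by the name of the read-out)), compound 1 stands second of the three numbers: compound 2 lies higher a number 36 percentage points higher from compound 1 to compound 2 (beyond the scatter) and compound 3 lies lower a number 45 percentage points lower from compound 1 to compound 3 (beyond the scatter). The unmeasured compound 4 `CCCCC(=O)OCc1c(C)nc2c(OCc3ccccc3)cccn12` differs from compound 1 in one place, as follows. ((butylcarbonyl)oxy)methyl in place of acetyl on an aromatic carbon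

Within the data shown here, two measured steps touch the same aromatic carbon: the change from acetyl to chloro, which raised the number a number 36 percentage points higher from compound 1 to compound 2 (beyond the scatter), and the change from acetyl to carboxymethyl, which lowered it a number 45 percentage points lower from compound 1 to compound 3 (beyond the scatter). Both were large, but neither introduces a ((butylcarbonyl)oxy)methyl group, so they show only that this position can swing the read-out strongly in either direction. Nothing measured points to a particular direction for compound 4, so the expected step of a number 7 percentage points lower from compound 1 to compound 4 (within the scatter) is given as none beyond the scatter, with a wide range. Compound 4 is therefore estimated at 50%, between 20% and 85%.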

Compound 4, a percentage reported as inhibition, in the whole organism at one dose (the size of the read-out at that dose, not a potency): 45%
Estimate against measurement, compound 4: 5 percentage points above, within the range that was stated.
By their numbers in this assay, from the lowest: compound 3; then compound 4; then compound 1; then compound 2.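

In this assay, putting ((butylcarbonyl)oxy)methyl on this aromatic carbon in place of acetyl brings only a modest change (a number 12 percentage points lower from compound 1 to compound 4 (beyond the scatter)), yet the same group falls far short of chloro (a number 48 percentage points lower from compound 2 to compound 4 (beyond the scatter)). Compound 3 and compound 4 both carry a saturated chain carbon on the aromatic carbon, and their large difference (a number 33 percentage points higher from compound 3 to compound 4 (beyond the scatter)) shows that such a carbon does not by itself fix the read-out: what it bears matters. No measurement at hand gives a reason for any of these steps.

The compounds shown leave open whether a hydroxymethyl or an aminomethyl group on this carbon would lie nearer to chloro or to carboxymethyl. They also leave open how a shorter or longer acyl chain, or bromo in place of chloro, would compare.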